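Swapping methoxy for fluoro on a saturated ring

The compounds below may be only part of what the source reports. "The series", "measured", "known", "first", "only" and "open" are said of these compounds alone.

Measured so far in an ADME assay on microsomes from liver (Mus musculus) for metabolic stability, with a stated time of 10 min; a higher number here means that more of the compound is left, a lower number that less of the compound is left:
Compound 1 `CC(=O)N1CCC(c2nnc3c(Oc4cccc(Cl)c4C)cccn23)CC1` gives 90%
Compound 2 `Cc1c(Cl)cccc1Oc1cccn2c(C34CCC(N)(CC3)CC4)nnc12` has the entry "not determined" (no result reported)
Compound 3 `COC12CCC(c3nnc4c(Oc5cccc(Cl)c5C)cccn34)(CC1)CC2` gives 70%

Compound 3 with 70% holds the lower of the two numbers, and compound 1 gives 90%. The gap between these two compounds lies beyond the scatter. Compound 4 `Cc1c(Cl)cccc1Oc1cccn2c(C34CCC(F)(CC3)CC4)nnc12` differs from compound 3 in one place: fluoro in place of methoxy on a saturated ring carbon with fluoro in place of methoxy on a saturated ring carbon. For the measured compounds named here, no measured pair shows this swap directly. Compound 1 with 90% as its result shows that a high number is possible in this small set, so a small rise is expected. The estimated step is a number 10 percentage points higher from compound 3 to compound 4 (within the scatter) and it may not clear the scatter. For compound 4 the estimated value is 80% with an expected range from 60% to 95% in this assay.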

Compound 4, percent of the compound remaining: 62%
The estimate for compound 4 lay 18 percentage points above the measured number, within the range that was stated.
By their numbers in this assay, from the lowest: compounds 4 and 3 (each within the scatter of the next); then compound 1.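

In this assay the swap of methoxy for fluoro on this saturated ring carbon gives a number 8 percentage points lower from compound 3 to compound 4 (within the scatter), so this one change does not separate the two groups here. Replacing the whole group on the aromatic carbon gives a clearer gap, a number 28 percentage points lower from compound 1 to compound 4 (beyond the scatter), which places the larger difference in that group rather than in the methoxy-to-fluoro swap. No measurement at hand gives a reason for either step. Still open, on these data alone, is how a hydroxyl or a carboxylic acid on the same ring carbon would compare with methoxy and fluoro.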